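The source may report more compounds than this note shows. Statements on the series, on what has been measured and on what is new or still open speak of the compounds shown alone.

Working notes on the series, followed in an in vitro assay on V79MZh cells for inhibition of cytochrome P450 11B1, mitochondrial (Homo sapiens); a higher number here means a weaker inhibitor, a lower number a stronger inhibitor. Compound 1 `CC(c1ccc(-c2ccccc2)nc1)n1ccnc1` gives 33 nM in this assay. Compound 2 `CC(c1ccc(-c2cccc3ccccc23)nc1)n1ccnc1` gives 60 nM in this assay; its number is the higher of the two recorded so far, but its nearest neighbour is compound 1 and the gap between them lies within the scatter, so no order between the two is read. Compound 3 `c1ccc2c(-c3ccc(C(C4CC4)n4ccnc4)cn3)cccc2c1` has not yet been measured. It differs from compound 2 by cyclopropyl in place of methyl on a saturated chain carbon bound to an aromatic carbon and an aromatic nitrogen. Within the data shown here, no measured pair shows this exchange, so its effect cannot be taken from the data; a step not beyond the scatter, in either direction, is expected, the step from compound 2 to compound 3 in this assay being estimated at a 1.2-fold lower number from compound 2 to compound 3 (0.08 log units; within the scatter). Compound 3 is accordingly expected to give 50 nM in this assay, with a range from 15 nM to 160 nM.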

Compound 3, half-maximal inhibitory concentration: 151 nM
Compound 3: the middle estimate sits 3.0-fold (0.48 log units) below what was measured; the range from low to high includes it.
By their numbers in this assay, from the lowest: compounds 1 and 2 (each within the scatter of the next); then compound 3.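

In this assay, the saturated chain carbon bound to an aromatic carbon and an aromatic nitrogen turns out to respond to substitution: cyclopropyl in place of methyl gives a 2.5-fold higher number from compound 2 to compound 3 (0.40 log units; beyond the scatter). Compounds 1 and 2 could not show this, as both carry methyl at this carbon and their values lie within the scatter of each other. The step is modest and rests on a single pair, so it describes this one exchange on the core of compound 2, not a trend. Nothing at hand bears on the origin of this step.

As far as these compounds go, it remains open whether ethyl or a bare hydrogen at this carbon would give a number closer to that of compound 2. From the compounds shown here alone, it also remains open whether the same exchange on the core of compound 1 would give a step of similar size.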